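The source may report more compounds than this note shows. Statements on the series, on what has been measured and on what is new or still open speak of the compounds shown alone.

Measured compounds:
compound 1 `Fc1cc(Cl)ccc1Cn1nnc2c(Br)cccc21` — 0.5 mL/min/g
compound 2 `FC(F)(F)c1cc(Br)c2nnn(CC3CC3)c2c1` — 0.1 mL/min/g

Both compounds were tested in an ADME assay on microsomes from liver (Homo sapiens) for metabolic stability, tested at 2.5 uM; a higher number here means faster removal of the compound, a lower number slower removal. Compound 2 gives 0.1 mL/min/g, the lower of the two numbers. Compound 1 gives 0.5 mL/min/g, and the gap between the two lies beyond the usual scatter of repeated measurements, so compound 2 stands clearly as the more slowly removed of the pair.

Compound 3 `Clc1cc(Br)c2nnn(CC3CC3)c2c1` has not yet been measured in this assay. It differs from compound 2 in a single place: chloro in place of trifluoromethyl on an aromatic carbon. For the measured compounds named here, no pair of measured compounds shows a step of this kind, so the two values above offer no direct guide to its size. The account expects a small step in this assay of a 1.5-fold higher number from compound 2 to compound 3 (0.18 log units; within the scatter), possibly upward, but not beyond the scatter. Compound 3 is therefore estimated at 0.15 mL/min/g, with a range from 0.05 mL/min/g to 0.45 mL/min/g.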

Compound 3, intrinsic clearance in a liver preparation (reported as CLH), per the amount of preparation that the assay uses: 0.5 mL/min/g
Compound 3: the middle estimate sits 3.3-fold (0.52 log units) below what was measured; measured number above the stated range.
By their numbers in this assay, from the lowest: compound 2; then compounds 1 and 3 (each within the scatter of the next).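

In this assay, for the compounds shown here, the replacement of trifluoromethyl by chloro on this aromatic carbon, para to a fused ring and meta to the bromo group, gives the first single-place step: a 5.0-fold higher number from compound 2 to compound 3 (0.70 log units; beyond the scatter). This shows that the group at this position matters in this assay, since the low number of compound 2 does not survive this one change while the rest of the molecule stays the same. Nothing measured here accounts for the size or direction of the step, so its cause remains unknown.

The compounds shown leave open where a nitrile, a methoxy group or a plain hydrogen at this carbon would fall relative to compound 2 and compound 3. They also leave open whether the same change gives a similar step when the bromo group is replaced by another group.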